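Trimethoxyphenyl replaces chlorophenyl on the carbonyl carbon

A few compounds are considered here, and "the series" means these few. Any claim that something is new, unique, unknown or untested is made for them only; others in the source may bear on it.

Three chalcone-like compounds on a shared core have been measured in a functional assay on MDA-MB-231 cells (Homo sapiens) for antiproliferative activity, read by MTT assay, with a stated time of 24 h; on this read-out lower numbers stand for stronger inhibition and higher numbers for weaker inhibition. Compound 1 `COc1ccc(-c2cc(/C=C/C(=O)c3cc(OC)c(OC)c(OC)c3)nc3cc(-c4ccccc4)nn23)cc1OC` gives 4700 nM. Compound 2 `COc1cc(-c2cc(/C=C/C(=O)c3ccc(C)c(C)c3)nc3cc(-c4ccccc4)nn23)cc(OC)c1OC` gives 13500 nM, and compound 3 `COc1cc(-c2cc(/C=C/C(=O)c3ccc(Cl)cc3)nc3cc(-c4ccccc4)nn23)cc(OC)c1OC` gives 32500 nM. Among these, compound 3 stands at the highest number, so it is the weakest of the three on this read-out, with compound 2 nearest to it and compound 1 furthest away.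

The next compound, compound 4 `COc1cc(C(=O)/C=C/c2cc(-c3cc(OC)c(OC)c(OC)c3)n3nc(-c4ccccc4)cc3n2)cc(OC)c1OC`, has not yet been measured. It is derived from compound 3 by a single change: 3,4,5-trimethoxyphenyl in place of 4-chlorophenyl on a carbonyl carbon. For the measured compounds named here, the only measured step that alters the same position is a 2.4-fold higher number from compound 2 to compound 3 (0.38 log units; beyond the scatter), which shows that the aryl group on the carbonyl carbon can move the number beyond the scatter. Going by the values given here, compound 1 also carries a 3,4,5-trimethoxyphenyl on its carbonyl carbon, though its other aryl group differs from that of compound 3, so no single step joins the two; their values nevertheless point in the same direction, toward a lower number with the trimethoxyphenyl.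

For compound 4 the expected step is therefore a 5.4-fold lower number from compound 3 to compound 4 (0.73 log units; beyond the scatter), a lower number in this assay. The estimate for compound 4 is 6000 nM, within a range from 2500 nM to 15000 nM.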

Compound 4, half-maximal inhibitory concentration: 24300 nM
Estimate against measurement, compound 4: 4.1-fold (0.61 log units) below, and the stated range ends below it.
By their numbers in this assay, from the lowest: compound 1; then compounds 2, 4 and 3 (each within the scatter of the next, the first and the last beyond it).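

Placing 3,4,5-trimethoxyphenyl on the carbonyl carbon in place of 4-chlorophenyl gives a 1.3-fold lower number from compound 3 to compound 4 (0.13 log units; within the scatter) in this assay, and placing it there in place of 3,4-dimethylphenyl gives a 1.8-fold higher number from compound 2 to compound 4 (0.26 log units; within the scatter), so on this core the trimethoxyphenyl group cannot be told apart from either of those two groups, even though 4-chlorophenyl and 3,4-dimethylphenyl themselves differ beyond the scatter. The trimethoxyphenyl on the carbonyl carbon therefore does not by itself go with the low number of compound 1: with that group held constant, methoxy in place of hydrogen on an aromatic carbon of the other aryl group gives a 5.2-fold higher number from compound 1 to compound 4 (0.71 log units; beyond the scatter), so this step, at a place away from the carbonyl carbon, is the one that lies beyond the scatter. No measurement shown here explains why these steps take the sizes they do.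

The compounds shown leave open whether the same methoxy change would give a step of similar size with 4-chlorophenyl or 3,4-dimethylphenyl on the carbonyl carbon. They also leave open how an aminophenyl or a carboxylic acid-bearing phenyl on the carbonyl carbon would read in this assay.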